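The source may report more compounds than this note shows. Statements on the series, on what has been measured and on what is new or still open speak of the compounds shown alone.

Of the compounds shown here, two have so far been measured in a functional assay on HTB-54 cells (Homo sapiens) for cytotoxicity, read by MTT assay, with a stated time of 72 h; a lower number here means a stronger inhibitor of growth, a higher number a weaker inhibitor of growth. Compound 1 `CCCCCCOC(=O)Nc1ccc([Se]C#N)cc1` gives 23600 nM there. Compound 2 `N#C[Se]c1ccc(NC(=O)Oc2ccc(Cl)cc2)cc1` gives 13800 nM in this assay, and this number lies within the usual scatter of that of compound 1, so the two cannot be ranked against each other. Compound 3 `N#C[Se]c1ccc(NC(=O)Oc2ccccc2)cc1` differs from compound 2 in a single place: hydrogen in place of chloro on an aromatic carbon. Among the measured compounds shown here, no measured pair shows this particular change, so there is no step to lean on. The step is expected to be small, a 1.3-fold higher number from compound 2 to compound 3 (0.12 log units; within the scatter), most likely within the scatter. Compound 3 is therefore estimated at 18000 nM, with a range from 8000 nM to 40000 nM.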

Compound 3, concentration for 50% growth inhibition: 26200 nM
Beside the measured number, compound 3's estimate is 1.5-fold (0.16 log units) below it; the range from low to high includes it.
By their numbers in this assay, from the lowest: compounds 2, 1 and 3 (each within the scatter of the next).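

In this assay the swap of chloro for hydrogen on the aromatic carbon gives a 1.9-fold higher number from compound 2 to compound 3 (0.28 log units; within the scatter) so this position shows no clear dependence on chloro. Phenyl in place of hexyl on the oxygen gives a 1.1-fold higher number from compound 1 to compound 3 (0.05 log units; within the scatter) so these two very different groups cannot be told apart here. Nothing available explains why these numbers lie so close. As far as these compounds go, whether an amine or a methoxy group at the chloro position would move the number beyond the scatter remains open. The same question stands for a longer chain on the oxygen.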